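Anilide series: aryl amide variation at the carbonyl carbon

The source may report more compounds than this note shows. Statements on the series, on what has been measured and on what is new or still open speak of the compounds shown alone.

Measured compounds:
compound 1 `CCC(=O)Nc1c(C(O)(C(F)(F)F)C(F)(F)F)ccc2ccccc12` — in an assay on LtK cells with ATP-sensitive inward rectifier potassium channel 11 (Homo sapiens) as the target (on this read-out higher numbers stand for an effect only at larger amounts of compound and lower numbers for an effect already at smaller amounts), compound 1 gives 15 nM
compound 2 `CCCC(C)C(=O)Nc1c(C(O)(C(F)(F)F)C(F)(F)F)ccc2ccccc12` — compound 2 reaches only the assay limit, > 10000 nM
compound 3 `O=C(Nc1c(C(O)(C(F)(F)F)C(F)(F)F)ccc2ccccc12)c1cccc(Cl)c1` — compound 3 gives 98 nM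

All three share the same core, differing only at the carbonyl carbon of the amide. Among the two compounds with a number, compound 3 stands highest; its nearest neighbour is compound 1, and the step of a 6.5-fold higher number from compound 1 to compound 3 (0.82 log units; beyond the scatter) follows the exchange of 3-chlorophenyl for ethyl. The value of compound 2 is a limit of the assay (the limit of > 10000 nM in this assay, at which 1 of the 3 values shown sits); the step of an at least 660-fold higher number from compound 1 to compound 2 (2.82 log units; beyond the scatter) is large, as is the step of an at least 100-fold lower number from compound 2 to compound 3 (2.00 log units; beyond the scatter).

Compound 4 `O=C(Nc1c(C(O)(C(F)(F)F)C(F)(F)F)ccc2ccccc12)c1ccc(C(F)(F)F)cc1` is not yet measured. It differs from compound 3 only by 4-(trifluoromethyl)phenyl in place of 3-chlorophenyl on a carbonyl carbon. Going by the values given here, the one measured step at this carbonyl carbon between two compounds with numbers, a 6.5-fold higher number from compound 1 to compound 3 (0.82 log units; beyond the scatter), shows that an aromatic group there already costs a modest amount relative to ethyl; no measured step compares two aryl groups against each other. A further modest rise is therefore expected rather than a large one, with the direction uncertain. For compound 4 the expected step is a 2.0-fold higher number from compound 3 to compound 4 (0.31 log units; beyond the scatter), giving an estimate of 200 nM with a range from 60 nM to 1000 nM.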

Compound 4, half-maximal effective concentration: 160 nM
Compound 4: middle estimate off by 1.3-fold (0.10 log units), on the high side, and the stated range covers the measured number.
By their numbers in this assay, from the lowest: compound 1; then compounds 3 and 4 (each within the scatter of the next). At a limit, above all of these: compound 2.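

In this assay, going by these compounds alone, a 1.6-fold higher number from compound 3 to compound 4 (0.21 log units; within the scatter) gives the first comparison of two aryl groups on the carbonyl carbon, and it shows that 3-chlorophenyl and 4-(trifluoromethyl)phenyl cannot be told apart here. Set against ethyl, the new aryl group gives an 11-fold higher number from compound 1 to compound 4 (1.03 log units; beyond the scatter), so compound 1 keeps the lowest number in the series and neither aryl amide matches it. Compound 2 remains at a limit of the assay rather than a number, so an at least 62-fold lower number from compound 2 to compound 4 (1.79 log units; beyond the scatter) is a bound and not a measured size: the limit of > 10000 nM in this assay, at which 1 of the 4 values shown sits.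

The two aryl groups differ in both the substituent and its ring position, so a 4-chlorophenyl or 3-(trifluoromethyl)phenyl group would be needed to separate those two changes, and an unsubstituted phenyl would show what either substituent contributes. On these data alone, the chain side also remains open: a methyl, propyl or isopropyl group on the carbonyl carbon could show where the sharp loss from the ethyl of compound 1 to the 1-methylbutyl of compound 2 sets in.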